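Compound 4: an isopropyl side chain on the shared core

This account rests on a few compounds, and the source may have more. Where it says the series, first, only, none or still open, it means among the compounds named here.

Three compounds that share one core and differ only in the side chain of the amino-acid part have been measured. Compound 1 `O=C(CN(c1ncnc2c1ncn2C1CCCCO1)C1CC1)N[C@@H](CO)C(=O)OCc1ccccc1` carries a hydroxy group there and gives 18.3% in a functional assay on the whole organism (Tail, strain ICR) with Mus musculus as the target, in the tail flick test, with a stated time of 150 min, at a dose of 25 umol/kg by the oral route; on this read-out higher numbers stand for a stronger effect at the one dose given and lower numbers for a weaker effect. Compound 2 `CC(C)(C)OC(=O)NCCCC[C@H](NC(=O)CN(c1ncnc2c1ncn2C1CCCCO1)C1CC1)C(=O)OCc1ccccc1` gives 17.2% in this assay, and compound 3 `N=C(N)NCCC[C@H](NC(=O)CN(c1ncnc2c1ncn2C1CCCCO1)C1CC1)C(=O)OCc1ccccc1` gives 19.6%. Compound 3 has the highest number of the three, but the gaps are small: a number 1.3 percentage points higher from compound 1 to compound 3 (within the scatter), a number 2.4 percentage points higher from compound 2 to compound 3 (within the scatter), and likewise a number 1.1 percentage points lower from compound 1 to compound 2 (within the scatter). None of these side-chain changes, whether toward more nitrogen or toward a larger carbamate-bearing chain, moved the read-out beyond the usual scatter.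

Compound 4 `CC(C)C[C@H](NC(=O)CN(c1ncnc2c1ncn2C1CCCCO1)C1CC1)C(=O)OCc1ccccc1` is the next step from compound 3. The change is a group of 3 heavy atoms (3 carbon; no ring) in place of a group of 6 heavy atoms (3 carbon, 3 nitrogen; no ring), on a saturated chain carbon, two bonds along the chain from an amide-type nitrogen and a carbonyl carbon. All three measured steps alter the same chain carbon and all stayed within the scatter, so the expectation for this further swap is a step of no clear size in either direction: the step expected from compound 3 to compound 4 is a number 1.6 percentage points lower from compound 3 to compound 4 (within the scatter). On that basis compound 4 is estimated to give about 18% in this assay, most likely between 9% and 28%.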

Compound 4, a percentage reported as activity, at one dose (the size of the read-out at that dose, not a potency): 6.47%
Compound 4: middle estimate off by 11.5 percentage points, on the high side, outside the stated range (below it).
By their numbers in this assay, from the lowest: compound 4; then compounds 2, 1 and 3 (each within the scatter of the next).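

In this assay, among the compounds shown here, the isopropyl group is the first change at this saturated chain carbon to move the number beyond the scatter, with steps of a number 13.1 percentage points lower from compound 3 to compound 4 (beyond the scatter) and a number 10.7 percentage points lower from compound 2 to compound 4 (beyond the scatter) and also a number 11.8 percentage points lower from compound 1 to compound 4 (beyond the scatter) setting compound 4 apart from all three earlier compounds. The position is therefore not indifferent to what it carries, even though hydroxy, 3-((tert-butoxycarbonyl)amino)propyl and the nitrogen-rich group of compound 3 stayed within the scatter of one another. Isopropyl is also the only one of these four groups made of carbon alone, but no measurement here explains the drop.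

As far as these compounds go, it remains open whether any group built only of carbon behaves this way or the drop belongs to isopropyl itself, which a methyl group, a longer carbon chain or a benzyl group at the same place could help to separate. A simple amine or a carboxylic acid there would show whether the earlier level returns with nitrogen or oxygen alone, and a single dose and time leave open how compound 4 behaves under other conditions.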